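The compounds below may be only part of what the source reports. "The series", "measured", "known", "first", "only" and "open" are said of these compounds alone.

Within the data shown here, in an ADME assay on Vero 76 cells (Chlorocebus sabaeus) for cytotoxicity, read by crystal violet staining, with a stated time of 96 h (a higher number here means that more compound is tolerated, a lower number that less compound is tolerated), compound 2 `FC(F)(F)c1cccc(NC(=S)Nc2ccccc2)c1` gives 39000 nM, the higher of the two numbers measured so far, while compound 1 `CCCC[C@H]1CC[C@H](c2ccc(NC(=S)Nc3cccc(C(F)(F)F)c3)cc2)CC1` gives 17000 nM. Compound 3 `FC(F)(F)c1cccc(NC(=S)Nc2cccc(Br)c2)c1` differs from compound 2 in one place: bromo in place of hydrogen on an aromatic carbon. In words, this is bromo in place of hydrogen on an aromatic carbon, turning phenyl into 3-bromophenyl. Among the measured compounds shown here, only one measured step bears on this change, and only loosely: a 2.3-fold higher number from compound 1 to compound 2 (0.36 log units; beyond the scatter), a modest step that came with hydrogen in place of 4-butylcyclohexyl on an aromatic carbon. Read in reverse, that step links adding a group to a lower number. Bromo is a much smaller addition, so a similar or smaller step towards a lower number is expected, and it may not exceed the scatter. The expected change is a 1.4-fold lower number from compound 2 to compound 3 (0.16 log units; within the scatter). For compound 3, the estimated value is 27000 nM, with an expected range of 12000 nM to 50000 nM.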

Compound 3, half-maximal cytotoxic concentration: 14000 nM
Compound 3: middle estimate off by 1.9-fold (0.29 log units), on the high side; the measured number falls inside the stated range.
By their numbers in this assay, from the lowest: compounds 3 and 1 (each within the scatter of the next); then compound 2.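

In this assay, the change from phenyl to 3-bromophenyl gives a 2.8-fold lower number from compound 2 to compound 3 (0.44 log units; beyond the scatter), so one bromine atom, meta to a large group, is enough to leave the scatter. The earlier pair had tied a lower number only to 4-butylcyclohexyl, a much larger group on the same ring, whereas this result shows that an addition of a single heavy atom on an aromatic carbon of that ring can also lower the number. No measurement at hand accounts for the size of this step.

Going by these compounds, whether the fall belongs to bromo itself or to any group at this place stays open, and a chloro, a methyl or a methoxy on the same carbon would test this. On these data alone, it is also open whether an amine or a carboxylic acid there would leave compound 2's 39000 nM unchanged or raise it.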